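This account rests on a few compounds, and the source may have more. Where it says the series, first, only, none or still open, it means among the compounds named here.

The measurements come from a toxicity assay on THP-1 cells (Homo sapiens) for inhibition; a higher number here means that more compound is tolerated, a lower number that less compound is tolerated. Compound 1 `COc1ccc(-c2nc3ncc(-c4ccc(F)cc4)cc3[nH]2)cc1` gives > 100000 nM, which is a limit of the test rather than a measured number. Compound 2 `CCC(=O)Nc1ncc(-c2ccc(OC)cc2)n1C` gives > 100000 nM, again a limit. Compound 3 `COc1ccc(-c2cnc(NC(=O)c3ccno3)n2C)cc1` gives > 100000 nM, once more a limit. Among the measured compounds shown here, because of the limit of > 100000 nM in this assay, at which 3 of the 3 values shown sit, no measured compound has yet given a readable number, and the only step between measured compounds, a step that the two limits leave unreadable from compound 2 to compound 3, cannot be sized. Compound 4 `COc1ccc(-c2cnc(NC(=O)c3cccc(C)c3)n2C)cc1` has not yet been tested. It differs from compound 3 in one place: 3-methylphenyl in place of 1,2-oxazol-5-yl on a carbonyl carbon. For the measured compounds named here, the only step that bears on this change, a step that the two limits leave unreadable from compound 2 to compound 3, also swapped the group on that carbonyl carbon, and both of its ends sit at the limit. Going by the values given here, with every value so far at the limit, no change beyond the scatter is expected in this assay; the expected step of a number no higher from compound 3 to compound 4 (the limit leaves the size open) is taken to stay within the scatter. Compound 4 is therefore estimated at 100000 nM, with a range from 50000 nM to 300000 nM, and is expected to be reported again as a limit.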

Compound 4, half-maximal cytotoxic concentration: > 100000 nM
Compound 4: no number, only a limit; the forecaster's own chance of this, stated with the estimate: 85%; the middle value sits exactly at the limit.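

Neither the comparison of compound 3 with compound 4 nor that of compound 2 with compound 4 gives a readable step, because all three compounds sit at the same limit: the limit of > 100000 nM in this assay, at which 4 of the 4 values shown sit. The compounds shown leave open whether any group on the carbonyl carbon changes what is tolerated in this assay.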